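This account rests on a few compounds, and the source may have more. Where it says the series, first, only, none or still open, it means among the compounds named here.

Compound 1, `OC(Cc1ccccc1)CN1CCC(NCCSC(c2ccc(F)cc2)c2ccc(F)cc2)CC1`: 31.4 nM
Compound 2, `O=C(c1ccc(F)cc1)N1CCC(NCCSC(c2ccc(F)cc2)c2ccc(F)cc2)CC1`: 7.04 nM
Compound 3, `Fc1ccc(C(SCCNC2CCN(Cc3cc4ccccc4[nH]3)CC2)c2ccc(F)cc2)cc1`: 179 nM

All three were tested in an assay on membranes from striatum (strain Sprague-Dawley) for displacement of a labelled ligand from sodium-dependent dopamine transporter (Rattus norvegicus), read by scintillation counting, with a stated time of 120 min; on this read-out higher numbers stand for weaker inhibition and lower numbers for stronger inhibition. Compound 3 gives the highest number of the set: a 5.7-fold higher number from compound 1 to compound 3 (0.76 log units; beyond the scatter), and a 25-fold higher number from compound 2 to compound 3 (1.41 log units; beyond the scatter), both beyond the scatter. Compound 4, `Fc1ccc(C(SCCNC2CCN(CC3CC3)CC2)c2ccc(F)cc2)cc1`, has not been measured. It differs from compound 3 in one place: cyclopropyl in place of 1H-indol-2-yl on a saturated chain carbon bound to an amine nitrogen in a ring. The two measured steps that touch this same place are the ones just described, modest in one case and large in the other, but neither introduces cyclopropyl, so the direction for compound 4 is not settled by them. As both earlier groups at this place sit lower than compound 3, a modest lowering is expected, a 3.0-fold lower number from compound 3 to compound 4 (0.47 log units; beyond the scatter). For compound 4 the estimate is 60 nM, within 15 nM to 250 nM.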

Compound 4, inhibition constant: 407 nM
Beside the measured number, compound 4's estimate is 6.8-fold (0.83 log units) below it, outside the stated range (above it).
By their numbers in this assay, from the lowest: compound 2; then compound 1; then compound 3; then compound 4.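

In this assay, replacing (1H-indol-2-yl)methyl with cyclopropylmethyl gives a 2.3-fold higher number from compound 3 to compound 4 (0.36 log units; beyond the scatter), so this place on the amine nitrogen in a ring does not favour the smaller-counted group here. The larger gaps, a 58-fold higher number from compound 2 to compound 4 (1.76 log units; beyond the scatter) and a 13-fold higher number from compound 1 to compound 4 (1.11 log units; beyond the scatter), widen the range seen at this place. Among these compounds, only compound 4 has no aromatic ring in this group, and it gives the highest number.

No evidence is available to explain these differences. Going by these compounds, whether a benzyl group would fall nearer compound 2 or a cyclohexylmethyl group nearer compound 4 remains open.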